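The compounds below may be only part of what the source reports. "The series", "measured", "known", "first", "only" and "open" are said of these compounds alone.

Among the measured compounds shown here, compound 3 `CCCCCCC(=O)c1cc(CC)c(OCCCCCC(C)(C)c2nnn[nH]2)cc1O` gives 8400 nM in an assay on isolated protein for antagonist activity at Bile acid receptor (Homo sapiens), read by HTRF, with a stated time of 30 min (a higher number here means a weaker inhibitor, a lower number a stronger inhibitor), the second highest of the three numbers measured so far; compound 1 `CCC(=O)c1cc(CC)c(OCCCCCC(C)(C)c2nnn[nH]2)cc1O` gives 8500 nM and compound 2 `CCCCC(=O)c1cc(CC)c(OCCCCCC(C)(C)c2nnn[nH]2)cc1O` gives 5400 nM, both within the scatter of compound 3. Compound 4 `CCc1cc(C(=O)c2ccccc2)c(O)cc1OCCCCCC(C)(C)c1nnn[nH]1` carries phenyl in place of hexyl on a carbonyl carbon. For the measured compounds named here, no measured step exchanges a saturated chain for an aromatic ring on this carbonyl carbon; the steps that alter only the chain length there, a 1.6-fold lower number from compound 1 to compound 2 (0.20 log units; within the scatter), a 1.0-fold lower number from compound 1 to compound 3 (0.01 log units; within the scatter) and a 1.6-fold higher number from compound 2 to compound 3 (0.19 log units; within the scatter), all lie within the scatter. On that basis the expected step is a 1.1-fold lower number from compound 3 to compound 4 (0.02 log units; within the scatter), essentially none beyond the scatter, with a wide range to reflect the untested change. Compound 4 is therefore expected to give 8000 nM, between 2500 nM and 25000 nM, in this assay.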

Compound 4, half-maximal inhibitory concentration: 3100 nM
For compound 4 the middle estimate is 2.6-fold (0.41 log units) above the measured one; the range from low to high includes it.
By their numbers in this assay, from the lowest: compounds 4, 2, 3 and 1 (each within the scatter of the next, the first and the last beyond it).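

On the carbonyl carbon, phenyl does what chain length alone did not: in this assay, phenyl in place of hexyl gives a 2.7-fold lower number from compound 3 to compound 4 (0.43 log units; beyond the scatter) and phenyl in place of ethyl gives a 2.7-fold lower number from compound 1 to compound 4 (0.44 log units; beyond the scatter), both modest steps beyond the scatter. Phenyl in place of butyl gives a 1.7-fold lower number from compound 2 to compound 4 (0.24 log units; within the scatter), so compound 4 and compound 2 are not separated, and the advantage holds only against hexyl and ethyl. No available measurement accounts for this difference.

Going by these compounds, whether a saturated ring such as cyclohexyl on this carbonyl carbon behaves like phenyl or like the chains remains open. On these data alone, the effect of a fluorine or a methoxy group on the phenyl ring is also open.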